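This account rests on a few compounds, and the source may have more. Where it says the series, first, only, none or still open, it means among the compounds named here.

Three analogues sharing one core have been run through an in vitro ADME assay on microsomes from liver (Homo sapiens) for metabolic stability; on this read-out lower numbers stand for a shorter-lived compound and higher numbers for a longer-lived compound. Compound 1 `COC[C@@H]1C[C@@H](C(=O)NCC2CCOCC2)CN(Cc2nc(-c3ccccc3)oc2C)C1` gives 0.0682 h in this assay. Compound 3 `Cc1cccc(CNC(=O)C2CCCN(Cc3nc(-c4ccccc4)oc3C)C2)n1` gives 0.096 h. Compound 2 `Cc1oc(-c2ccccc2)nc1CN1CCC[C@@H](C(=O)NC[C@@H]2CCCO2)C1` gives 0.235 h and stands highest of the three, with compound 3 nearest to it and compound 1 furthest away, both differences lying beyond the scatter.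

Compound 4 `Cc1oc(-c2ccccc2)nc1CN1CCC[C@@H](C(=O)NCc2cccc(N)n2)C1` has not yet been measured. Its relation to compound 2 is a single change: 6-aminopyridin-2-yl in place of oxolan-2-yl on a saturated chain carbon bound to an amide-type nitrogen. Compound 3, which also carries a pyridin-2-yl ring on the amide side, sits clearly lower than compound 2, so a step from compound 2 to compound 4 in the downward direction is expected, of a size near the edge of what repeat measurements can resolve; the step of a 2.0-fold lower number from compound 2 to compound 4 (0.29 log units; within the scatter) is the estimate. Compound 4 is therefore expected to give 0.12 h in this assay, with a plausible range from 0.05 h to 0.3 h.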

Compound 4, half-life: 0.342 h
Estimate against measurement, compound 4: 2.9-fold (0.45 log units) below; the whole stated range lies below it.
By their numbers in this assay, from the lowest: compounds 1 and 3 (each within the scatter of the next); then compounds 2 and 4 (each within the scatter of the next).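

In this assay, replacing oxolan-2-yl with 6-aminopyridin-2-yl on a saturated chain carbon bound to an amide-type nitrogen gives a 1.5-fold higher number from compound 2 to compound 4 (0.16 log units; within the scatter). For the compounds shown here, this is the first comparison here in which only one place differs, and it shows that this position accepts a six-membered aromatic ring in place of a five-membered non-aromatic one, along with the loss of a defined stereocentre, without a difference that repeat measurements could resolve. No supporting data are available to explain this result.

The compounds shown leave open what the amino group itself contributes, which an unsubstituted pyridin-2-yl or a phenyl group at the same place would address. They also leave open whether any ring is needed there at all, which an open chain such as 2-methoxyethyl would test.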